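A few compounds are considered here, and "the series" means these few. Any claim that something is new, unique, unknown or untested is made for them only; others in the source may bear on it.

Compound 1 `COC(=O)NC1=CS(=O)(=O)O[C@@]12[C@@H](CO[Si](C)(C)C(C)(C)C)O[C@@H](n1cc(C)c(=O)n(C)c1=O)[C@@H]2O[Si](C)(C)C(C)(C)C` — >= 50000 nM
Compound 2 `Cc1cn([C@@H]2O[C@H](CO[Si](C)(C)C(C)(C)C)[C@@]3(OS(=O)(=O)C=C3NCCC(=O)OCc3ccccc3)[C@H]2O[Si](C)(C)C(C)(C)C)c(=O)n(C)c1=O` — >= 400000 nM
Compound 3 `Cc1cn([C@@H]2O[C@H](CO[Si](C)(C)C(C)(C)C)[C@@]3(OS(=O)(=O)C=C3NCC(=O)C(N)=O)[C@H]2O[Si](C)(C)C(C)(C)C)c(=O)n(C)c1=O` — >= 16000 nM

In a functional assay on HEL cells (Homo sapiens) for cytotoxicity, read by microscopy (on this read-out lower numbers stand for higher toxicity in this test and higher numbers for lower toxicity in this test), compound 1 gives >= 50000 nM, which is a limit of the assay and not a number. Compound 2 gives >= 400000 nM, also a limit. Compound 3 gives >= 16000 nM, again a limit. So every value shown is a limit, and compound 1 stands only at its limit with nothing to order it against the other two. The steps between them, a step that the two limits leave unreadable from compound 1 to compound 2, a step that the two limits leave unreadable from compound 1 to compound 3 and a step that the two limits leave unreadable from compound 2 to compound 3, remain unreadable for this reason (the limit of >= 16000 nM in this assay, at which 1 of the 3 values shown sits, (the limit of >= 400000 nM in this assay, at which 1 of the 3 values shown sits), (the limit of >= 50000 nM in this assay, at which 1 of the 3 values shown sits)).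

Compound 4 `COC(=O)CCNC1=CS(=O)(=O)O[C@@]12[C@@H](CO[Si](C)(C)C(C)(C)C)O[C@@H](n1cc(C)c(=O)n(C)c1=O)[C@@H]2O[Si](C)(C)C(C)(C)C` differs from compound 1 in one place: 2-(methoxycarbonyl)ethyl in place of methoxycarbonyl on an amine nitrogen. The closest measured change, from compound 1 to compound 2, is the same kind of amine substitution and gave no readable step. Going by the values given here, no measured step therefore bears a size on this change, and the expectation is that compound 4 will again show no toxicity within the assay's window. Compound 4 is thus estimated at 60000 nM, which for the expected step means a step that the limit leaves unreadable from compound 1 to compound 4, most likely reported as a limit once more.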

Compound 4, minimum cytotoxic concentration: >= 400000 nM
Compound 4 was reported as a limit (the forecaster's own chance of this, stated with the estimate: 85%); middle value at least 6.6-fold (0.82 log units) away from the limit.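

In this assay compound 4 gives >= 400000 nM, which is a limit of the assay and not a number. Going by these compounds alone, no step from compound 4 to compound 1, compound 2 or compound 3 can be read. The compounds shown leave open whether changing the group on the amine nitrogen alters the minimum cytotoxic concentration at all.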